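Linker swap at the anilino position of the shared core

A few compounds are considered here, and "the series" means these few. Any claim that something is new, unique, unknown or untested is made for them only; others in the source may bear on it.

Compound 2 `CN(Cc1ccc(C(=O)O)cc1)c1ccc(OCc2c(-c3c(Cl)cccc3Cl)noc2C2CC2)nc1C(F)(F)F` gives 30 nM in a functional assay on HEK293 cells for agonist activity at Bile acid receptor (Homo sapiens); a higher number here means that more compound is needed for the effect, a lower number that less compound is needed; it carries the lowest number of the three, with compound 1 `CC(C)c1onc(-c2c(Cl)cccc2Cl)c1COc1ccc(N(C)Cc2ccc(CCC(=O)O)cc2)c(C(F)(F)F)n1` at 35 nM within the scatter of it, and compound 3 `CCN(Cc1ccc(C(=O)O)cc1)c1ccc(OCc2c(-c3c(Cl)cccc3Cl)noc2C2CC2)nc1C(F)(F)F` at 180 nM well above. For the measured compounds named here, the one measured step, a 6.0-fold higher number from compound 2 to compound 3 (0.78 log units; beyond the scatter), shows that enlarging the alkyl on the ring nitrogen costs potency. Compound 4 `CC(Oc1ccc(C(=O)O)cc1)c1ccc(OCc2c(-c3c(Cl)cccc3Cl)noc2C2CC2)nc1C(F)(F)F` replaces the whole linker: 1-(4-carboxyphenoxy)ethyl in place of (4-carboxybenzyl)(methyl)amino on an aromatic carbon. Going by the values given here, no measured step tests the oxygen-for-nitrogen exchange; the step from compound 2 to compound 3 is the only guide to changes at this position, and it points to a loss. A moderate loss is therefore expected, a 3.3-fold higher number from compound 2 to compound 4 (0.52 log units; beyond the scatter), with compound 4 estimated at 100 nM (range 30 nM to 400 nM) in this assay.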

Compound 4, half-maximal effective concentration: 189 nM
Estimate against measurement, compound 4: 1.9-fold (0.28 log units) below; low and high end bracket the measured number.
By their numbers in this assay, from the lowest: compounds 2 and 1 (each within the scatter of the next); then compounds 3 and 4 (each within the scatter of the next).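

Replacing the whole linker gives a 6.3-fold higher number from compound 2 to compound 4 (0.80 log units; beyond the scatter) in this assay, so at this aromatic carbon, the nitrogen-containing (4-carboxybenzyl)(methyl)amino group cannot be exchanged for 1-(4-carboxyphenoxy)ethyl without a loss beyond the scatter. Unlike the earlier step, this change removes the linker nitrogen itself and keeps the carboxyphenyl end. No evidence on hand accounts for the loss. The single step does not separate the oxygen-for-nitrogen exchange from the rearranged linker, and the compounds shown leave open how a 4-carboxyphenoxymethyl group or an amide linker would read in this assay at this position.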